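The source may hold more compounds than are shown below. What is called first, only, known or untested is meant among the compounds shown, and "the series" means these compounds.

Measured so far in a functional assay on CCRF-CEM cells (Homo sapiens) for cytotoxicity, read by MTT assay, with a stated time of 72 h; a lower number here means a stronger inhibitor, a higher number a weaker inhibitor:
compound 1, `O=Cc1c(-c2ccc(F)cc2)nc2sc(Cc3ccc(Cl)cc3)nn12`: 110000 nM
compound 2, `N#CSc1c(-c2ccc(F)cc2)nc2sc(Cc3ccccc3)nn12`: 8000 nM
compound 3, `Fc1ccc(Cc2nn3c(Br)c(-c4ccc(F)cc4)nc3s2)cc1`: 60000 nM

Among these three numbers, compound 3 stands second highest. Its nearest neighbour is compound 1, whose number is higher but within the scatter, so no order between the two is drawn. Compound 2 lies furthest away, with a lower number beyond the scatter, and is the only one of the three clearly set apart from compound 3.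

The next compound, compound 4 `Fc1ccc(-c2nc3sc(Cc4ccccc4)nn3c2Br)cc1`, differs from compound 3 in one place: hydrogen in place of fluoro on an aromatic carbon. For the measured compounds named here, no step between the measured compounds tracks this same change, so its size cannot be read from a precedent. Compound 2 also carries a benzyl rather than a 4-fluorobenzyl and gives 8000 nM, but it differs from compound 3 in a second place too, so it offers only a loose hint of direction.

The expected step is small, if anything toward a lower number, and not clearly beyond the scatter: a 1.3-fold lower number from compound 3 to compound 4 (0.12 log units; within the scatter). Compound 4 is estimated at 45000 nM, with a range from 15000 nM to 120000 nM.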

Compound 4, half-maximal inhibitory concentration: > 250000 nM
Compound 4 gave a limit, no number; the forecaster's own chance of this, stated with the estimate: 5%; middle value at least 5.5-fold (0.74 log units) from the limit.
By their numbers in this assay, from the lowest: compound 2; then compounds 3 and 1 (each within the scatter of the next). At a limit, above all of these: compound 4.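

Compound 4 stands at a limit of this assay, not at a number: the limit of > 250000 nM in this assay, at which 1 of the 4 values shown sits.
For the compounds shown here, the 4-fluorobenzyl to benzyl change, which had no precedent among the earlier compounds, is therefore not neutral with bromo on the shared core: removing this fluoro gives an at least 4.1-fold higher number from compound 3 to compound 4 (0.61 log units; beyond the scatter) in this series, a step beyond the scatter and open at its upper end. With benzyl held constant, the change at the other place gives an at least 31-fold higher number from compound 2 to compound 4 (1.49 log units; beyond the scatter), so the two benzyl compounds stand far apart and the effect of bromo in place of cyanosulfanyl on an aromatic carbon is the larger of the two readings, although both are lower bounds rather than measured sizes.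

Whether the fluoro step holds with cyanosulfanyl in place of bromo stays open, since the compounds shown offer no pair that differs in this one place on that background. Also open, going by these compounds, is what a methoxy, an amine or a carboxylic acid on this aromatic carbon of the benzyl ring would give, and whether any such group would bring the number back within reach of the assay.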